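Chloro for methoxy: expected step in the electroshock model

The source may hold more compounds than are shown below. What is called first, only, known or untested is meant among the compounds shown, and "the series" means these compounds.

Measured so far in a functional assay on the whole organism (strain Swiss) with Mus musculus as the target, in the maximal electroshock model, with a stated time of 0.5 h, at a dose of 300 mg/kg by the intraperitoneal route; a higher number here means a stronger effect of the compound at the dose given, a lower number a weaker effect:

Compound 1 `CCC(C(=O)N1CCN(c2cccc(Cl)c2)CC1)N1C(=O)CCC1=O` gives 50%
Compound 2 `COc1cccc(N2CCN(C(=O)C(C)N3C(=O)CCC3=O)CC2)c1` gives 50%
Compound 3 `COCC(C(=O)N1CCN(c2cccc(C(F)(F)F)c2)CC1)N1C(=O)CCC1=O` gives 50%

Compound 2 stands level with compounds 1 and 3 at the digits shown. Its nearest neighbour on the numbers is compound 1, with no change at the digits shown and within the scatter; its furthest is compound 3, again with no change at the digits shown and within the scatter. The three values therefore give no ordering among the measured compounds.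

Compound 4 `CC(C(=O)N1CCN(c2cccc(Cl)c2)CC1)N1C(=O)CCC1=O` has not yet been measured. It differs from compound 2 in one place: chloro in place of methoxy on an aromatic carbon. The site is an aromatic carbon of a six-membered aromatic ring of carbon only, meta to a large group. Within the data shown here, no step between two measured compounds isolates this change, so no measured step can be quoted for it. Compound 1 also carries a chloro group on that ring and gives 50%, the same figure as the other two.

On this basis no step beyond the scatter is expected in this assay for the change from compound 2 to compound 4. The expected step is no change at the digits printed from compound 2 to compound 4 (within the scatter). For compound 4 an activity of 50% is estimated, with a range from 30% to 70%.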

Compound 4, a percentage reported as activity, at one dose (the size of the read-out at that dose, not a potency): 100%
Estimate against measurement, compound 4: 50 percentage points below, and the stated range ends below it.
By their numbers in this assay, from the lowest: compounds 1, 2 and 3 (each within the scatter of the next); then compound 4.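

In this assay, the aromatic carbon is a sensitive site in this series: the change from 3-methoxyphenyl to 3-chlorophenyl gives a number 50 percentage points higher from compound 2 to compound 4 (beyond the scatter). The chloro group does not settle the read-out alone, as the saturated chain carbon also matters: hydrogen in place of methyl at that carbon, with the chloro group kept, gives a number 50 percentage points higher from compound 1 to compound 4 (beyond the scatter). Nothing at hand accounts for either step.

Going by these compounds, it remains open whether a bromo group or a nitrile on the same aromatic carbon, or a longer chain on the saturated carbon, would keep the read-out of compound 4. On these data alone, each read-out also stands at a single dose, so the potency of compound 4 relative to its neighbours remains unknown.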